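Trifluoromethyl gives way to methoxycarbonyl on the shared core

The compounds below may be only part of what the source reports. "The series", "measured", "known", "first", "only" and "open" are said of these compounds alone.

Measured in a physicochemical assay for solubility, with a stated time of 4 h, at pH 2.0; on this read-out higher numbers stand for higher solubility and lower numbers for lower solubility:
compound 1 `CNC(=O)c1cc(N)c(Nc2ccc(C#N)cc2)cc1Oc1c(C)cc(CCC#N)cc1C`: 44.7 ug/mL
compound 2 `Cc1cc(CCC#N)cc(C)c1Oc1cc(Nc2ccc(C#N)cc2)c(N)cc1C(F)(F)F`: 0.33 ug/mL

Of these two, compound 2 holds the lowest number, 0.33 ug/mL. The compound still to be measured is compound 3 `COC(=O)c1cc(N)c(Nc2ccc(C#N)cc2)cc1Oc1c(C)cc(CCC#N)cc1C`. It carries methoxycarbonyl in place of trifluoromethyl on an aromatic carbon, para to a (4-cyanophenyl)amino group: methoxycarbonyl in place of trifluoromethyl on an aromatic carbon. Among the measured compounds shown here, only one measured step bears on this change. It is a 140-fold lower number from compound 1 to compound 2 (2.13 log units; beyond the scatter), a large step beyond the scatter, with trifluoromethyl in place of methylcarbamoyl on the same aromatic carbon. Read in reverse, that step points to a higher number when trifluoromethyl leaves. However, the entering group here is methoxycarbonyl, not methylcarbamoyl, and no measured compound carries it. A rise beyond the scatter in this assay is expected, though a smaller one than that measured step. The estimated change is a 9.1-fold higher number from compound 2 to compound 3 (0.96 log units; beyond the scatter). For compound 3 the expected value is 3 ug/mL, with an estimated range of 0.7 ug/mL to 15 ug/mL.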

Compound 3, solubility: 21.8 ug/mL
For compound 3 the middle estimate is 7.3-fold (0.86 log units) below the measured one, and the stated range ends below it.
By their numbers in this assay, from the lowest: compound 2; then compound 3; then compound 1.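

In this assay, methoxycarbonyl in place of trifluoromethyl, para to a (4-cyanophenyl)amino group, gives a 66-fold higher number from compound 2 to compound 3 (1.82 log units; beyond the scatter), so a large rise on losing trifluoromethyl at this position is no longer tied to methylcarbamoyl alone. Methoxy in place of methylamino on the carbonyl carbon gives a 2.1-fold lower number from compound 1 to compound 3 (0.31 log units; beyond the scatter), a modest step beyond the scatter and much smaller than the step from trifluoromethyl. Nothing available here accounts for either step.

The compounds shown leave open whether other groups at this position, such as a carboxylic acid, an ethyl ester or an unsubstituted amide, would fall near compound 1 and compound 3 or nearer compound 2. They also leave open whether these steps would keep their size with a different group in place of the nitrile on the propyl chain.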